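The source may report more compounds than this note shows. Statements on the series, on what has been measured and on what is new or still open speak of the compounds shown alone.

Working notes on the series. Compound 2 `Cc1cccc(C(=O)Nc2ccc3c(c2)CC(CNS(C)(=O)=O)C3)c1-c1ccc(C(F)(F)F)cc1` gives 150 nM in an assay on isolated protein for inhibition of microsomal triglyceride transfer protein large subunit (Homo sapiens); a lower number here means a stronger inhibitor, a higher number a weaker inhibitor. Among the three measured compounds it stands second highest: compound 1 `COC(=O)NCC1Cc2ccc(NC(=O)c3cccc(C)c3-c3ccc(C(F)(F)F)cc3)cc2C1` gives 24 nM, and compound 3 `Cc1cccc(C(=O)Nc2ccc3c(c2)CC(CNS(C)(=O)=O)C3)c1-c1ccc(Cl)cc1` gives 500 nM. The two measured steps are a 6.3-fold higher number from compound 1 to compound 2 (0.80 log units; beyond the scatter) and a 3.3-fold higher number from compound 2 to compound 3 (0.52 log units; beyond the scatter). Compound 4 `COC(=O)NCCC1Cc2ccc(NC(=O)c3cccc(C)c3-c3ccc(C(F)(F)F)cc3)cc2C1` is not yet measured; it differs from compound 2 by ((methoxycarbonyl)amino)methyl in place of methanesulfonamido on a saturated chain carbon bound to a saturated ring carbon. Among the compounds with values here, the step from compound 1 to compound 2 bears on this: it is the same exchange of groups on the amine nitrogen run in the other direction, though compound 4 carries the entering group one bond further out, and no measured pair covers that extension. The step from compound 2 to compound 3 touches a different part of the molecule and does not bear on it. The exchange is therefore expected to lower the number in this assay by roughly the size seen from compound 1 to compound 2, with a wider range to allow for the longer chain. For compound 4 the expected value is 35 nM, between 12 nM and 120 nM. The expected step is a 4.3-fold lower number from compound 2 to compound 4 (0.63 log units; beyond the scatter).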

Compound 4, half-maximal inhibitory concentration: 70 nM
Estimate against measurement, compound 4: 2.0-fold (0.30 log units) below; the range from low to high includes it.
By their numbers in this assay, from the lowest: compound 1; then compound 4; then compound 2; then compound 3.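

In this assay the chain length at this position matters on its own, since adding one carbon with the methoxycarbonyl amine unchanged gives a 2.9-fold higher number from compound 1 to compound 4 (0.46 log units; beyond the scatter). The methoxycarbonyl group on the longer chain still gives the lower number against the shorter methanesulfonamido compound, with a 2.1-fold lower number from compound 2 to compound 4 (0.33 log units; beyond the scatter), a smaller step than a 6.3-fold higher number from compound 1 to compound 2 (0.80 log units; beyond the scatter), though this new step combines the exchange of groups with the added chain carbon. No measurement at hand offers an explanation for either step.

Still open, on these data alone, is how a 2-(methanesulfonamido)ethyl group would compare at the same chain length, which would separate the effect of the group from that of the chain. Also open, as far as these compounds go, is whether a 3-((methoxycarbonyl)amino)propyl chain or a free primary amine would continue the trend.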